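This account rests on a few compounds, and the source may have more. Where it says the series, first, only, none or still open, it means among the compounds named here.

- Compound 1 `CCn1cc(C(=O)O)c(=O)c2cc(F)c(N3CCN(C(=N)NS(=O)(=O)c4cccc(Cl)c4)CC3)cc21`: 71 nM
- Compound 2 `N=C(NS(=O)(=O)c1cccc(Cl)c1)N1CCN(c2cc3c(cc2F)c(=O)c(C(=O)O)cn3C2CC2)CC1`: 71 nM

In a functional assay on A549 cells (Homo sapiens) for antiproliferative activity, read by MTT assay, with a stated time of 72 h (on this read-out higher numbers stand for weaker inhibition and lower numbers for stronger inhibition), compound 1 gives 71 nM, and it stands level with compound 2 at 71 nM. The next compound to be tested is compound 3 `CCn1cc(C(=O)O)c(=O)c2cc(F)c(N3CCN(C(=N)NS(=O)(=O)c4ccccc4C(F)(F)F)CC3)cc21`, which keeps the core of compound 1 and alters only the aryl group: 2-(trifluoromethyl)phenyl in place of 3-chlorophenyl on a sulfonyl sulfur. In words, 2-(trifluoromethyl)phenyl takes the place of 3-chlorophenyl on a sulfonyl sulfur. Among the compounds with values here, the one measured step, no change at the digits printed from compound 1 to compound 2 (within the scatter), swaps ethyl for cyclopropyl on an aromatic nitrogen and leaves that aryl group untouched. Within the data shown here, it therefore says little about this change, and no measured step varies the aryl group. No step beyond the scatter is expected in this assay, and the data favour no direction. The estimated step is a 1.3-fold higher number from compound 1 to compound 3 (0.10 log units; within the scatter). For compound 3 the expected value is 90 nM, with an estimated range of 25 nM to 320 nM.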

Compound 3, half-maximal inhibitory concentration: 71 nM
Beside the measured number, compound 3's estimate is 1.3-fold (0.10 log units) above it; measured number inside the range.
By their numbers in this assay, from the lowest: compounds 1, 2 and 3 (each within the scatter of the next).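

In this assay, within the data shown here, the first measured change to the aryl group on the sulfonyl sulfur gives no change at the digits printed from compound 1 to compound 3 (within the scatter) when 2-(trifluoromethyl)phenyl takes the place of 3-chlorophenyl. The earlier pair varied only the group on the aromatic nitrogen, whereas this pair shows that this place accepts a different substituted phenyl group, with more heavy atoms, without a step beyond the scatter. Nothing shown gives a reason for this result.

The substituent and its ring position differ together in this one pair, so their contributions cannot be separated. As far as these compounds go, it remains open whether the same holds for a phenyl ring carrying an amine or a carboxylic acid, for a pyridine ring, or for a longer alkyl chain on the sulfonyl sulfur.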